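The source may hold more compounds than are shown below. What is called first, only, known or untested is meant among the compounds shown, and "the series" means these compounds.

Measured in a functional assay on KB cells (Homo sapiens) for cytotoxicity; a lower number here means a stronger inhibitor, a higher number a weaker inhibitor:
compound 1 `COc1ccc(S(=O)(=O)N2CCc3cccc(NC(=O)c4cccs4)c32)cc1`: 47 nM
compound 2 `COc1ccc(S(=O)(=O)N2CCc3cccc(NC(=O)c4ccc(F)cc4)c32)cc1`: 93 nM

Among the measured compounds shown here, the scale holds only two numbers so far. For the measured compounds named here, the single measured step, a 2.0-fold higher number from compound 1 to compound 2 (0.30 log units; within the scatter), does not separate them, so compound 2 stands level with its only neighbour.

Next is compound 3 `COc1ccc(S(=O)(=O)N2CCc3cccc(NC(=O)c4ccncc4)c32)cc1`, with pyridin-4-yl in place of 4-fluorophenyl on a carbonyl carbon. Going by the values given here, the one measured step bears directly on this change, as it also swaps the ring on that carbonyl carbon, and it stayed within the scatter. A single step is thin evidence, but it gives no reason to expect a large shift in this assay. The value of compound 1, 47 nM, gives only a weak lean towards a lower number. The expected change is a 1.9-fold lower number from compound 2 to compound 3 (0.27 log units; within the scatter), and no step beyond the scatter is expected. For compound 3 the estimate is 50 nM, with an expected range of 12 nM to 200 nM.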

Compound 3, half-maximal inhibitory concentration: 9.6 nM
Beside the measured number, compound 3's estimate is 5.2-fold (0.72 log units) above it, outside the stated range (below it).
By their numbers in this assay, from the lowest: compound 3; then compounds 1 and 2 (each within the scatter of the next).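

In this assay, the ring on the carbonyl carbon now proves able to move the number: pyridin-4-yl in place of 4-fluorophenyl gives a 9.7-fold lower number from compound 2 to compound 3 (0.99 log units; beyond the scatter), and pyridin-4-yl in place of thiophen-2-yl gives a 4.9-fold lower number from compound 1 to compound 3 (0.69 log units; beyond the scatter), whereas the earlier ring swap stayed within the scatter. With both steps beyond the scatter, compound 3 stands as the most potent of the three compounds shown, and this position is sensitive to the identity of the ring. No measurement shown accounts for this difference.

Open, going by these compounds, is whether the place of the ring nitrogen matters, since pyridin-3-yl and pyridin-2-yl would test this directly on the same carbonyl carbon. Also open, on these data alone, is how plain phenyl or a saturated ring such as piperidin-4-yl would compare with compound 3.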